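Ester variation in the oxadiazolone series: mouse microsomal stability

The source may report more compounds than this note shows. Statements on the series, on what has been measured and on what is new or still open speak of the compounds shown alone.

Compound 1 `CCCCc1nc(C(C)C)c(CC(=O)OCC(F)(F)F)c(=O)n1Cc1ccc(-c2ccccc2-c2noc(=O)[nH]2)cc1` carries a 2,2,2-trifluoroethyl ester; in an ADME assay on microsomes from liver (Mus musculus) for metabolic stability, with a stated time of 30 min (on this read-out higher numbers stand for a more stable compound and lower numbers for a less stable compound), compound 1 gives "not determined" (no result reported), so it has no number to stand on. The two esters that do have numbers are compound 2 `CCCCCOC(=O)Cc1c(C(C)C)nc(CCCC)n(Cc2ccc(-c3ccccc3-c3noc(=O)[nH]3)cc2)c1=O`, which gives 19.7% in this assay, and compound 3 `CCCCc1nc(C(C)C)c(CC(=O)OCC(C)C)c(=O)n1Cc1ccc(-c2ccccc2-c2noc(=O)[nH]2)cc1`, which gives 13.7% in this assay. Among the compounds with values here, the one measured step, a number 6 percentage points lower from compound 2 to compound 3 (within the scatter), is within the scatter and gives no direction. Compound 4 `CCCCc1nc(C(C)C)c(CC(=O)OC(CC)CC)c(=O)n1Cc1ccc(-c2ccccc2-c2noc(=O)[nH]2)cc1` differs from compound 1 by pentan-3-yl in place of 2,2,2-trifluoroethyl on an oxygen next to a carbonyl group. Within the data shown here, no measured step covers a fluorinated ester, so the only guide is that compound 2 and compound 3, both plain alkyl esters of the shared core, fall close together. Compound 4 is expected to land in the same region, with an estimate of 20% in this assay and a range from 8% to 40%.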

Compound 4, percent of the compound remaining: 14.6%
The estimate for compound 4 lay 5.4 percentage points above the measured number, and the stated range covers the measured number.
By their numbers in this assay, from the lowest: compounds 3, 4 and 2 (each within the scatter of the next).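

In this assay, pentan-3-yl on an oxygen next to a carbonyl group does not separate from the other plain alkyl esters: the result is a number 0.9 percentage points higher from compound 3 to compound 4 (within the scatter) and a number 5.1 percentage points lower from compound 2 to compound 4 (within the scatter) in the two comparisons. Pentyl, isobutyl and pentan-3-yl therefore give values within the scatter of one another, so this position shows no readable change among these three alkyl groups, although it now spans a third alkyl shape. No measurement offered here explains this lack of separation.

With no number for compound 1, the change from 2,2,2-trifluoroethyl to pentan-3-yl cannot be read. On these data alone, whether a carboxylic acid in place of the ester, or an ester group carrying an amine, would leave this narrow range remains open.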